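This account rests on a few compounds, and the source may have more. Where it says the series, first, only, none or still open, it means among the compounds named here.

In a functional assay on A-431 cells (Homo sapiens) for inhibition (a lower number here means a stronger inhibitor, a higher number a weaker inhibitor), compound 1 `CCCCCCC[C@H]1O[C@@H]2OC(=O)N(C(=O)CCl)[C@@H]2CC1=O` gives 79000 nM and compound 2 `CCCCCCC[C@@]1(C)O[C@@H]2OC(=O)N(C(=O)CCl)[C@@H]2CC1=O` gives 78000 nM. These two values lie within the scatter of each other, so compound 2 stands level with compound 1. Compound 3 `CCCCCC#C[C@@]1(C)O[C@@H]2OC(=O)N(C(=O)CCl)[C@@H]2CC1=O` differs from compound 2 as follows: hept-1-yn-1-yl in place of heptyl on a saturated ring carbon. For the measured compounds named here, no measured pair tests this change, so no shift beyond the scatter is expected in this assay. The estimated move is a 1.2-fold lower number from compound 2 to compound 3 (0.08 log units; within the scatter). For compound 3 the expected value is 65000 nM, with an estimated range of 25000 nM to 150000 nM.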

Compound 3, half-maximal inhibitory concentration: 47000 nM
Compound 3: the middle estimate sits 1.4-fold (0.14 log units) above what was measured; the measured number falls inside the stated range.
By their numbers in this assay, from the lowest: compounds 3, 2 and 1 (each within the scatter of the next).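

In this assay, hept-1-yn-1-yl in place of heptyl on this saturated ring carbon, next to the ring oxygen, gives a 1.7-fold lower number from compound 2 to compound 3 (0.22 log units; within the scatter). The triple bond is therefore accommodated at this position without a shift that can be told from the scatter. Nothing available explains why the two chains read alike.

Still open, going by these compounds, is whether a much shorter or longer chain at this carbon moves the number beyond the scatter. Also open, on these data alone, is what an amine or a carboxylic acid at the chain end would do.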